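Hydroxy to Ethyl on the Alkyne Chain

The compounds below may be only part of what the source reports. "The series", "measured", "known", "first", "only" and "open" are said of these compounds alone.

Measured compounds:
compound 1 `CC#CCc1cn([C@H]2C[C@H](O)[C@@H](CO)O2)c(=O)[nH]c1=O` gives > 1000 ug/mL in a functional assay on L1210 cells (Mus musculus); on this read-out higher numbers stand for weaker inhibition and lower numbers for stronger inhibition.
compound 2 `O=c1[nH]c(=O)n([C@H]2C[C@H](O)[C@@H](CO)O2)cc1C#CCO` gives > 1000 ug/mL in this assay.

Compound 2 sits only at a limit of the assay, not at a number. Compound 1 likewise sits only at a limit. The step that the two limits leave unreadable from compound 1 to compound 2 is therefore unreadable. Compound 3 `CCCC#Cc1cn([C@H]2C[C@H](O)[C@@H](CO)O2)c(=O)[nH]c1=O` differs from compound 2 by ethyl in place of hydroxy on a saturated chain carbon bound to a triple-bonded carbon. Within the data shown here, no measured step bears readably on this change, since (the limit of > 1000 ug/mL in this assay, at which 2 of the 2 values shown sit). For compound 3 no more than an unchanged reading is expected, a step that the limit leaves unreadable from compound 2 to compound 3. Compound 3 is estimated at 1500 ug/mL, between 300 ug/mL and 5000 ug/mL.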

Compound 3, concentration for 50% inhibition: > 1000 ug/mL
Compound 3: a limit, no number; the forecaster's own chance of this, stated with the estimate: 75%; the middle value does not contradict the limit.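

No step can be read among compound 1, compound 2 and compound 3, since each gives only a limit in this assay, not a number: the limit of > 1000 ug/mL in this assay, at which 3 of the 3 values shown sit.

What stays open is how strongly any of these compounds inhibits, and whether ethyl in place of hydroxy changes that at all.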